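A few compounds are considered here, and "the series" means these few. Any claim that something is new, unique, unknown or untested is made for them only; others in the source may bear on it.

In a functional assay on MGC-803 cells (Homo sapiens) for inhibition, read by sulforhodamine B assay (on this read-out lower numbers stand for stronger inhibition and higher numbers for weaker inhibition), compound 3 `CCc1ccc(NC2=CC(=O)c3nc4n(c3C2=O)[C@H]2OC[C@@H](O)[C@H]2OC4)cc1` gives 1290 nM, the second highest of the three numbers measured: compound 1 `Cc1ccc(NC2=CC(=O)c3nc4n(c3C2=O)[C@H]2OC[C@@H](O)[C@H]2OC4)cc1C` gives 860 nM and compound 2 `COc1ccc(NC2=CC(=O)c3c(nc4n3[C@H]3OC[C@@H](O)[C@H]3OC4)C2=O)cc1` gives 2150 nM, and both lie within the scatter of compound 3. Compound 4 `COc1ccc(NC2=CC(=O)c3nc4n(c3C2=O)[C@H]2OC[C@@H](O)[C@H]2OC4)cc1` arises from compound 3 by a single change, (methoxy in place of ethyl on an aromatic carbon). Among the compounds with values here, the only measured step touching the group on that aromatic ring is a 1.5-fold higher number from compound 1 to compound 3 (0.18 log units; within the scatter), which stayed within the scatter. Compound 2 carries the same methoxy-bearing group on a differently joined core and gives 2150 nM. Within the data shown here, no measured step tests this exact exchange, so the expected step of a 1.2-fold higher number from compound 3 to compound 4 (0.07 log units; within the scatter) is none beyond the scatter. Compound 4 is therefore estimated at 1500 nM, within 600 nM to 3800 nM.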

Compound 4, half-maximal inhibitory concentration: 1680 nM
The estimate for compound 4 lay 1.1-fold (0.05 log units) below the measured number, and the stated range covers the measured number.
By their numbers in this assay, from the lowest: compounds 1, 3, 4 and 2 (each within the scatter of the next, the first and the last beyond it).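

In this assay, exchanging ethyl for methoxy on the shared core, which brings in a hydrogen-bond acceptor, gives a 1.3-fold higher number from compound 3 to compound 4 (0.11 log units; within the scatter), so this position accepts the exchange without a change that can be told from the scatter. Changing the 3,4-dimethylphenyl group to 4-methoxyphenyl gives a 2.0-fold higher number from compound 1 to compound 4 (0.29 log units; within the scatter), which also stays within the scatter. Nothing available explains why these groups read alike. Still open, on these data alone, is whether an amine, a carboxylic acid or a longer chain on this same aromatic carbon would move the number beyond the scatter.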